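The source may hold more compounds than are shown below. What is called first, only, known or untested is meant among the compounds shown, and "the series" means these compounds.

Compound 1: `COc1cc(-n2cnc3ccc(-c4ccccc4Cl)cc32)cc(OC)c1OC` — > 10000 nM
Compound 2: `COc1ccc(-c2ccc3ncn(-c4cc(OC)c(OC)c(OC)c4)c3c2)cc1F` — 520 nM

In a functional assay on MCF7 cells (Homo sapiens) for antiproliferative activity, read by MTT assay, with a stated time of 72 h (a lower number here means a stronger inhibitor, a higher number a weaker inhibitor), compound 1 reaches only the limit of the assay, > 10000 nM, and gives no number. Compound 1 thus sits at the weak end of the two values shown, at the limit (the limit of > 10000 nM in this assay, at which 1 of the 2 values shown sits). In this assay compound 2 gives 520 nM. Going by the values given here, the single measured step between these two, an at least 19-fold lower number from compound 1 to compound 2 (1.28 log units; beyond the scatter), runs towards a stronger inhibitor and is large.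

Compound 3 `COc1cc(-n2cnc3ccc(-c4cc(F)ccc4F)cc32)cc(OC)c1OC` has not yet been measured in this assay. It differs from compound 1 in one place: 2,5-difluorophenyl in place of 2-chlorophenyl on an aromatic carbon. The entering group is a 2,5-difluorophenyl, not the 3-fluoro-4-methoxyphenyl that marks compound 2, so the measured step bears on this change only loosely; the two structures share the shared core and the replacement of 2-chlorophenyl, nothing more. Compound 3 is therefore expected to stay close to where compound 1 stands, with a step of an at least 1.2-fold lower number from compound 1 to compound 3 (0.09 log units; that floor lies within the scatter) that may not exceed the scatter. Compound 3 is estimated at 8000 nM in this assay, within a range of 2000 nM to 30000 nM.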

Compound 3, half-maximal inhibitory concentration: 6420 nM
Beside the measured number, compound 3's estimate is 1.2-fold (0.10 log units) above it; measured number inside the range.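

In this assay, the change from 2-chlorophenyl to 2,5-difluorophenyl on this aromatic carbon gives an at least 1.5-fold lower number from compound 1 to compound 3 (0.19 log units; that floor lies within the scatter), so compound 3 gives a measured number, but the step does not establish a gain beyond the scatter. The value for compound 1 remains a limit, not a number: the limit of > 10000 nM in this assay, at which 1 of the 3 values shown sits. The new comparison with compound 2 shows more clearly that the choice of substituted phenyl at this place matters, with a 12-fold higher number from compound 2 to compound 3 (1.09 log units; beyond the scatter); among the compounds shown, the 2,5-difluorophenyl of compound 3 does not match the 3-fluoro-4-methoxyphenyl of compound 2, although both groups carry fluorine.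

The compounds shown do not separate the contribution of the methoxy group in compound 2 from that of its fluorine, nor do they show whether the placing of the substituents on the phenyl ring matters apart from their identity. Going by these compounds, it also remains open how this position would respond to a phenyl bearing only a methoxy group, or to one bearing an amine or a carboxylic acid.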